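The compounds below may be only part of what the source reports. "The series", "measured", "known", "first", "only" and "open" are said of these compounds alone.

In a functional assay for antagonist activity at transient receptor potential cation channel subfamily V member 1 (Rattus norvegicus) (a lower number here means a stronger inhibitor, a higher number a weaker inhibitor), compound 1 `C[C@@H]1CN(c2ncccc2C(F)(F)F)CCN1C(=O)Nc1ccc(C(F)(F)F)cc1` gives 11 nM. Compound 2 `CC(C)(C)c1ccc(NC(=O)c2ccc(-c3ccccn3)cc2)cc1` gives 8 nM in this assay, a value within the usual scatter of that of compound 1, so the two compounds cannot be told apart on these numbers. Compound 3 `CC(C)(C)c1ccc(NC(=O)c2ccc(-c3ncccc3N(S(C)(=O)=O)S(C)(=O)=O)cc2)cc1` differs from compound 2 by bis(methylsulfonyl)amino in place of hydrogen on an aromatic carbon. Going by the values given here, no measured pair shows such a change, so its effect is open. A weakening step a 7.5-fold higher number from compound 2 to compound 3 (0.88 log units; beyond the scatter) is expected here, given the size of the group entering. Compound 3 is accordingly estimated at 60 nM, with a range from 10 nM to 400 nM.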

Compound 3, half-maximal inhibitory concentration: 0.4 nM
For compound 3 the middle estimate is 150-fold (2.18 log units) above the measured one; the whole stated range lies above it.
By their numbers in this assay, from the lowest: compound 3; then compounds 2 and 1 (each within the scatter of the next).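

In this assay, placing bis(methylsulfonyl)amino in place of hydrogen on an aromatic carbon, ortho to a large group and two atoms from the ring nitrogen, brings a 20-fold lower number from compound 2 to compound 3 (1.30 log units; beyond the scatter). Going by these compounds alone, this position therefore accepts a large group with no loss of strength, which the earlier compounds could not show, since compound 2 carries only hydrogen there. Nothing at hand gives a reason for this step. On these data alone, whether a single methylsulfonylamino group, an amine or a methyl group on this carbon would act alike stays open.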